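Swapping the ether-linked bicycle in a weakly binding pair

The source may report more compounds than this note shows. Statements on the series, on what has been measured and on what is new or still open speak of the compounds shown alone.

Measured compounds:
compound 1, `Cc1ncc2nccn2c1-c1ccc(Oc2nccc3occc23)cc1C(F)(F)F`, 8800 nM
compound 2, `FC(F)(F)c1cc(Oc2nccc3occc23)ccc1-c1cccc2nccn12`, 7400 nM

In an assay on cells for displacement of a labelled ligand from Alpha-1B adrenergic receptor (Homo sapiens), read by scintillation counting, with a stated time of 90 min (on this read-out lower numbers stand for stronger inhibition and higher numbers for weaker inhibition), compound 1 gives 8800 nM and compound 2 gives 7400 nM. Within the data shown here, compound 2 stands at the lowest of the two numbers, but the only measured step, a 1.2-fold lower number from compound 1 to compound 2 (0.08 log units; within the scatter), is within the scatter, so the two compounds are not separated on this read-out.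

Compound 3, `FC(F)(F)c1cc(Oc2nccc3ccsc23)ccc1-c1cccc2nccn12`, keeps the whole of compound 2 except for one change: a group of 9 heavy atoms (7 carbon, 1 nitrogen, 1 sulfur; one five-membered aromatic ring with 1 hetero atom, one six-membered aromatic ring with 1 hetero atom) in place of a group of 9 heavy atoms (7 carbon, 1 nitrogen, 1 oxygen; one five-membered aromatic ring with 1 hetero atom, one six-membered aromatic ring with 1 hetero atom), on an oxygen on an aromatic ring, on an oxygen on an aromatic ring whose other neighbour is an aromatic carbon. Among the measured compounds shown here, no measured step touches this part of the molecule; the one step in hand, from compound 1 to compound 2, alters the other end and was itself within the scatter. There is therefore no basis for expecting a shift beyond the scatter in this assay, and compound 3 is expected to stay close to compound 2, with a step of about a 1.1-fold lower number from compound 2 to compound 3 (0.02 log units; within the scatter). The estimate for compound 3 in this assay is 7000 nM, with a range from 3000 nM to 18000 nM.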

Compound 3, inhibition constant: 4800 nM
Estimate against measurement, compound 3: 1.5-fold (0.16 log units) above; the measured number falls inside the stated range.
By their numbers in this assay, from the lowest: compounds 3, 2 and 1 (each within the scatter of the next).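

Among these compounds, this is the first change at this place, on an oxygen on an aromatic ring, and in this assay exchanging the group carrying 1 oxygen for the one carrying 1 sulfur gives a 1.5-fold lower number from compound 2 to compound 3 (0.19 log units; within the scatter). The two groups match in heavy-atom count, ring types and counted hydrogen-bond acceptors, so this step tests little more than the exchange of that one hetero atom, and on this read-out it does not separate the two compounds. Together with a 1.2-fold lower number from compound 1 to compound 2 (0.08 log units; within the scatter), which alters the other end of the molecule, it means that neither single change shown moves the number beyond the scatter, and no other data are available to explain the small differences seen.

The compounds shown leave open whether a group of a different kind at this place, such as a simple phenyl ring or one carrying an amine or a carboxylic acid, would shift the number beyond the scatter. They also leave open whether the same exchange of oxygen for sulfur would give a similar step when made on compound 1.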